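A few compounds are considered here, and "the series" means these few. Any claim that something is new, unique, unknown or untested is made for them only; others in the source may bear on it.

In a functional assay on HCT-116 cells (Homo sapiens) for antiproliferative activity, read by MTT assay, with a stated time of 72 h (on this read-out lower numbers stand for stronger inhibition and higher numbers for weaker inhibition), compound 2, with the structure `COc1cccc(N2C(=O)COc3ccc(-c4cnc(OC)c(NS(=O)(=O)c5ccc(F)cc5)c4)cc32)c1`, gives only a limit of the assay, > 40000 nM. That limit is the one described by the limit of > 40000 nM in this assay, at which 1 of the 3 values shown sits. Compound 1, with the structure `COc1ncc(-c2ccc3c(c2)NC(=O)CO3)cc1NS(=O)(=O)c1ccc(F)cc1`, gives in this assay 24900 nM. The two differ in one place, as described by hydrogen in place of 3-methoxyphenyl on an amide-type nitrogen in a ring, and the step between them is an at least 1.6-fold lower number from compound 2 to compound 1 (0.20 log units; that floor lies within the scatter), which is not large enough to be told apart from repeat scatter.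

Compound 3, with the structure `COc1cccc(N2C(=O)COc3ccc(-c4ccc(O)cc4)cc32)c1`, gives in this assay 15300 nM. The difference between the core of compound 3 and the core of compound 2 is not broken down here; the two share only the part that carries the lactam ring. Compound 4, with the structure `O=C1COc2ccc(-c3ccc(O)cc3)cc2N1`, is not yet measured. It is related to compound 3 by the change (hydrogen in place of 3-methoxyphenyl on an amide-type nitrogen in a ring), which is the same change that leads from compound 2 to compound 1, at the same place in the same kind of ring.

Because the measured step of an at least 1.6-fold lower number from compound 2 to compound 1 (0.20 log units; that floor lies within the scatter) is small and sits at a limit, the estimated step from compound 3 to compound 4 is likewise expected to be modest, about a 1.5-fold lower number from compound 3 to compound 4 (0.18 log units; within the scatter). On that basis compound 4 is expected to give about 10000 nM in this assay, with a plausible span from 4000 nM to 30000 nM.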

Compound 4, half-maximal inhibitory concentration: > 40000 nM
Compound 4: only a limit was reported (the forecaster's own chance of this, stated with the estimate: 15%); at least 4.0-fold (0.60 log units) between middle value and limit.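

In this assay, putting hydrogen in place of 3-methoxyphenyl on the amide-type nitrogen gives an at least 2.6-fold higher number from compound 3 to compound 4 (0.41 log units; beyond the scatter), so on the core of compound 3 this change goes with weaker inhibition, and the real step may be larger, since the value of compound 4 is only a limit of the assay. The same change therefore does not carry over from one core to the other with the same effect, and a step read on one core would have been a poor guide to the other: the same change on two cores in this assay, an at least 1.6-fold lower number (0.20 log units; that floor lies within the scatter) from compound 2 to compound 1 and an at least 2.6-fold higher number (0.41 log units; beyond the scatter) from compound 3 to compound 4, at least 4.1-fold (0.62 log units) apart, beyond the scatter of two such steps What this does not show is the true size of either step, or which feature of the cores decides the outcome, since only two cores are compared and each step rests on a limit rather than on two numbers: the limit of > 40000 nM in this assay, at which 2 of the 4 values shown sit.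

The compounds shown leave open how the amide-type nitrogen of either core would respond to other groups, such as a plain methyl, an unsubstituted phenyl or a longer chain ending in an amine. A third core carrying both 3-methoxyphenyl and hydrogen at this place, with both values inside the range of the assay, would help show how far the change depends on the core.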